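A few compounds are considered here, and "the series" means these few. Any claim that something is new, unique, unknown or untested is made for them only; others in the source may bear on it.

In a functional assay on DU-145 cells (Homo sapiens) for cytotoxicity, read by MTT assay (a lower number here means a stronger inhibitor, a higher number a weaker inhibitor), compound 1 `CC(C)=CC[C@@H](OC(=O)CCO)C1=CC(=O)c2c(O)ccc(O)c2C1=O` gives 55300 nM and compound 2 `CCCC(C)(O)CC(=O)O[C@H](CC=C(C)C)C1=CC(=O)c2c(O)ccc(O)c2C1=O` gives 75000 nM, and these two values lie within the scatter of each other. Compound 3 `CC(C)=CC[C@@H](OC(=O)CC(C)(O)c1ccccc1)C1=CC(=O)c2c(O)ccc(O)c2C1=O` differs from compound 2 by one change: phenyl in place of propyl on a saturated chain carbon bound to an oxygen on a saturated carbon and two saturated chain carbons. Among the measured compounds shown here, the only measured step that bears on this is a 1.4-fold higher number from compound 1 to compound 2 (0.13 log units; within the scatter), so no step beyond the scatter is expected in this assay. The expected value for compound 3 is 55000 nM, within an estimated range of 22000 nM to 120000 nM. This estimate means an expected 1.4-fold lower number from compound 2 to compound 3 (0.13 log units; within the scatter).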

Compound 3, half-maximal inhibitory concentration: > 100000 nM
Compound 3 was reported as a limit (the forecaster's own chance of this, stated with the estimate: 10%); at least 1.8-fold (0.25 log units) between middle value and limit.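

In this assay compound 3 gives > 100000 nM, which is a limit and not a number. Phenyl in place of propyl gives an at least 1.3-fold higher number from compound 2 to compound 3 (0.12 log units; that floor lies within the scatter), while 1-hydroxy-1-phenylethyl in place of hydroxymethyl gives an at least 1.8-fold higher number from compound 1 to compound 3 (0.25 log units; that floor lies within the scatter). This position thus carries an aromatic ring for the first time, with no gain in potency, and the true size of both steps stays hidden: the limit of > 100000 nM in this assay, at which 1 of the 3 values shown sits.

The compounds shown leave open how far compound 3 really lies past its limit. They also leave open whether an amine, a carboxylic acid or a chain longer than propyl in place of phenyl would move the number beyond the scatter.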